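Mirror-Image Twin of Compound 3 at the Alpha3/Beta4 Receptor

This account rests on a few compounds, and the source may have more. Where it says the series, first, only, none or still open, it means among the compounds named here.

Of the compounds shown here, three have been measured so far in a functional assay on HEK293 cells for agonist activity at Neuronal acetylcholine receptor; alpha3/beta4 (Homo sapiens), read by FLIPR; on this read-out lower numbers stand for an effect already at smaller amounts and higher numbers for an effect only at larger amounts of compound. Compound 1 `COc1cc(N2C[C@H]3CCNC[C@H]32)cnc1Br` gives 202 nM, compound 2 `N#Cc1cncc(N2C[C@H]3CCNC[C@H]32)c1` gives 5560 nM, and compound 3 `N#Cc1cc(N2C[C@@H]3CCNC[C@@H]32)cnc1Br` gives 794 nM. Compound 3 therefore stands second highest of the three numbers: its nearest neighbour is compound 1, whose number is lower by an amount beyond the usual scatter, and its furthest is compound 2, whose number is higher, also beyond the scatter.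

Compound 4 `N#Cc1cc(N2C[C@H]3CCNC[C@H]32)cnc1Br` is the unmeasured partner. It differs from compound 3 as follows: the two compounds have the same atoms and bonds and differ only in configuration as drawn: 2 of 2 stereo elements differ (all stereocentres are inverted: mirror images); a stereocentre at a saturated ring carbon is drawn S in compound 3 and R in compound 4; a stereocentre at a saturated ring carbon is drawn R in compound 3 and S in compound 4. The two are mirror images, nothing added, nothing removed.

Among the measured compounds shown here, no measured pair in this set shows what inverting both stereocentres does in this assay, so the direction of the step cannot be read from the data. Mirror images of the same molecule often act differently on a receptor, so a step beyond the scatter in this assay is expected, in either direction. As a balanced guess, compound 4 is estimated at 450 nM, with a range from 80 nM to 4000 nM, which would mean an expected step of a 1.8-fold lower number from compound 3 to compound 4 (0.25 log units; within the scatter).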

Compound 4, half-maximal effective concentration: 238 nM
Beside the measured number, compound 4's estimate is 1.9-fold (0.28 log units) above it; the range from low to high includes it.
By their numbers in this assay, from the lowest: compounds 1 and 4 (each within the scatter of the next); then compound 3; then compound 2.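

Inverting both stereocentres gives a 3.3-fold lower number from compound 3 to compound 4 (0.52 log units; beyond the scatter), and this step can only come from the arrangement of the atoms in space because of one fact: the fact that compounds 3 and 4 differ only in the configuration as drawn

Within the configuration of compound 4, bromo in place of hydrogen on an aromatic carbon gives a 23-fold lower number from compound 2 to compound 4 (1.37 log units; beyond the scatter), so this halogen matters far more than the earlier compounds could show. By contrast, cyano in place of methoxy on an aromatic carbon gives a 1.2-fold higher number from compound 1 to compound 4 (0.07 log units; within the scatter), so in this configuration the two groups cannot be told apart.

From the compounds shown here alone, it remains open whether inverting both stereocentres would give a step of similar size and direction in a compound carrying methoxy or lacking bromo. Going by these compounds, it is also open how chloro or an amine would fare in place of bromo.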